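Adding a second chloro to the shared core: UACC-62 growth inhibition

The source may report more compounds than this note shows. Statements on the series, on what has been measured and on what is new or still open speak of the compounds shown alone.

Measured in a functional assay on UACC-62 cells (Homo sapiens) for cytotoxicity, read by sulforhodamine B assay, with a stated time of 48 h; a lower number here means a stronger inhibitor of growth, a higher number a weaker inhibitor of growth:
compound 1, `ClCc1cccc(Cn2cnc3ncnc(Cl)c32)c1`, gives 5370 nM
compound 2, `ClCc1ccccc1Cn1cnc2ncnc(Cl)c21`, gives 5120 nM
compound 3, `ClCc1cccc(Cn2cnc3nc(Cl)nc(Cl)c32)c1`, gives 2180 nM

Compound 1 and compound 2 are built from the same atoms joined differently; the difference between the two cores is not broken down here. In this assay the two give numbers within the scatter of each other, so nothing separates them on this read-out.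

Compound 3 carries one change relative to compound 1, (chloro in place of hydrogen on an aromatic carbon), and that change made a step of a 2.5-fold lower number from compound 1 to compound 3 (0.39 log units; beyond the scatter). Whether the same change behaves the same on the core of compound 2 is the open point.

Compound 4, `ClCc1ccccc1Cn1cnc2nc(Cl)nc(Cl)c21`, differs from compound 2 by chloro in place of hydrogen on an aromatic carbon. The place of the change is the same, word for word, as in the pair of compound 1 and compound 3, so this is the same change carried onto the other core.

Within the data shown here, the step from compound 2 to compound 4 is expected to be a 2.4-fold lower number from compound 2 to compound 4 (0.39 log units; beyond the scatter), close to the earlier one, because the only measured instance of this change is a 2.5-fold lower number from compound 1 to compound 3 (0.39 log units; beyond the scatter). That rests on a single pair and on compound 2 starting where compound 1 starts. Compound 4 is therefore estimated to give about 2100 nM in this assay. The range for compound 4 is estimated to run from 1000 nM to 4500 nM.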

Compound 4, concentration for total growth inhibition: 2810 nM
The estimate for compound 4 lay 1.3-fold (0.13 log units) below the measured number, and the stated range covers the measured number.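

Carried onto the core of compound 2, chloro in place of hydrogen on an aromatic carbon, between two ring nitrogen atoms, gives in this assay a 1.8-fold lower number from compound 2 to compound 4 (0.26 log units; within the scatter), a step that on its own does not clear the scatter. Set beside the earlier instance, the two steps cannot be told apart: the same change on two cores in this assay, a 2.5-fold lower number (0.39 log units; beyond the scatter) from compound 1 to compound 3 and a 1.8-fold lower number (0.26 log units; within the scatter) from compound 2 to compound 4, 1.4-fold (0.13 log units) apart, within the scatter of two such steps. This fits the change carrying over from one core to the other in direction and rough size, but it does not show that the change has a firm effect on the core of compound 2, and two pairs on two closely related cores say nothing about any further core or about why the numbers move.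

The compounds shown leave open whether a group other than chloro at this place, such as an amine or a methoxy group, would shift the number in this assay in the same way as chloro. They also leave open how much the chloromethyl group carried by all four compounds contributes, which a hydroxymethyl group or a longer chain in its place would test.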